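A few compounds are considered here, and "the series" means these few. Any claim that something is new, unique, unknown or untested is made for them only; others in the source may bear on it.

Of the compounds shown here, three of a shared core have been measured in a functional assay on A-375 cells (Homo sapiens) for antiproliferative activity, read by CCK-8 assay, with a stated time of 72 h, tested at 2 uM; on this read-out lower numbers stand for a weaker effect and higher numbers for a stronger effect at the one concentration tested. Compound 1 `Nc1ccccc1NC(=O)c1ccc(CSC(=S)N2CCN(c3ccc(Cl)cc3)CC2)cc1` gives 32.2% in this assay. Compound 3 `Nc1ccccc1NC(=O)c1ccc(CSC(=S)N2CCN(Cc3ccncc3)CC2)cc1` gives 33.1%. Compound 2 `CC1CCCCN1C(=S)SCc1ccc(C(=O)Nc2ccccc2N)cc1` gives 42.5%, which is the highest of the three numbers; its gap to compound 3 lies within the scatter, while its gap to compound 1 lies beyond it. Going by the values given here, the only measured step that changes a single place is a number 0.9 percentage points higher from compound 1 to compound 3 (within the scatter), and it lies within the scatter.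

Compound 4 `Nc1ccccc1NC(=O)c1ccc(CSC(=S)N2CCc3ccccc32)cc1` is not yet measured. It differs from compound 2 in one place: 2,3-dihydro-1H-indol-1-yl in place of 2-methylpiperidin-1-yl on a thiocarbonyl carbon. Among the compounds with values here, no measured step touches the group on the thiocarbonyl carbon, so nothing among the measured compounds bears directly on this change; the one measured step concerns another part of the molecule and was small. He therefore expects compound 4 to stay near compound 2, with a step of a number 4.5 percentage points lower from compound 2 to compound 4 (within the scatter) in this assay, in no particular direction beyond the scatter. His estimate for compound 4 is 38%, with a range from 24% to 52%.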

Compound 4, a percentage reported as inhibition, at one concentration (the size of the read-out at that concentration, not a potency): 25.7%
Beside the measured number, compound 4's estimate is 12.3 percentage points above it; measured number inside the range.
By their numbers in this assay, from the lowest: compounds 4, 1, 3 and 2 (each within the scatter of the next, the first and the last beyond it).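

In this assay, 2,3-dihydro-1H-indol-1-yl in place of 2-methylpiperidin-1-yl on a thiocarbonyl carbon gives a number 16.8 percentage points lower from compound 2 to compound 4 (beyond the scatter), so this position does respond to a change of group. Going by these compounds alone, the one earlier single-place step, a number 0.9 percentage points higher from compound 1 to compound 3 (within the scatter), concerned a group on an amine nitrogen in a ring and did not touch this place. No measurement at hand accounts for the size or direction of the new step.

The compounds shown leave open whether the step goes with the six-membered aromatic ring that enters or with the methyl-bearing piperidine ring that leaves. Going by these compounds, it also remains open how a plain piperidin-1-yl or a morpholin-4-yl on the same thiocarbonyl carbon would read in this assay, which would help separate these two parts of the change.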